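Sulfur-linked chain ending in an acid on the shared core

This account rests on a few compounds, and the source may have more. Where it says the series, first, only, none or still open, it means among the compounds named here.

Compound 1 `CCCCCCCNc1cc(-c2ccccc2)c(-c2ccccc2)nn1`: 55000 nM
Compound 2 `CCCCCC(=O)Nc1cc(-c2ccccc2)c(-c2ccccc2)nn1`: > 300000 nM
Compound 3 `CCCCCCCSc1cc(-c2ccccc2)c(-c2ccccc2)nn1`: 76000 nM

In an assay on microsomes from liver for inhibition of sterol O-acyltransferase 1 (Rattus norvegicus) (on this read-out lower numbers stand for stronger inhibition and higher numbers for weaker inhibition), compound 3 gives 76000 nM. Compound 1 gives 55000 nM, and the step of a 1.4-fold higher number from compound 1 to compound 3 (0.14 log units; within the scatter) stays within the scatter, so these two values cannot be ordered. Compound 2 gives > 300000 nM, which is a limit of the assay rather than a number. The steps of an at least 5.4-fold higher number from compound 1 to compound 2 (0.73 log units; beyond the scatter) and an at least 3.9-fold lower number from compound 2 to compound 3 (0.59 log units; beyond the scatter) are both beyond the scatter.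

Compound 4 `O=C(O)CCCCCSc1cc(-c2ccccc2)c(-c2ccccc2)nn1` differs from compound 3 by carboxy in place of ethyl on a saturated chain carbon, five bonds along the chain from a sulfur. Among the measured compounds shown here, none of the measured steps changes the end of the chain; the step from compound 1 to compound 3 concerns only the atom that links the chain to the core, and the other two steps concern the amide. So no measured step bears directly on this change, and the expectation rests on thin ground. Compound 4 is estimated to give 150000 nM, between 40000 nM and 500000 nM, an expected step of a 2.0-fold higher number from compound 3 to compound 4 (0.30 log units; within the scatter). A result at the limit of > 300000 nM in this assay, at which 1 of the 3 values shown sits, is also possible.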

Compound 4, half-maximal inhibitory concentration: > 300000 nM
Compound 4: only a limit was reported (the forecaster's own chance of this, stated with the estimate: 30%); middle value at least 2.0-fold (0.30 log units) away from the limit.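

In this assay, carboxy in place of ethyl at the end of the sulfur-linked chain is the only change to the chain end among the compounds shown, and it weakens inhibition: an at least 3.9-fold higher number from compound 3 to compound 4 (0.59 log units; beyond the scatter). The step of an at least 5.4-fold higher number from compound 1 to compound 4 (0.73 log units; beyond the scatter) points the same way but changes the linking atom as well as the chain end, while changing the linking atom alone gives a 1.4-fold higher number from compound 1 to compound 3 (0.14 log units; within the scatter). The value of compound 4 is a limit and not a number, as is that of compound 2, so the step between them cannot be read: the limit of > 300000 nM in this assay, at which 2 of the 4 values shown sit.

Still open, from the compounds shown here alone, is whether a methyl ester, a primary amide or an amine at the same chain end would behave like the carboxy group. Also open, going by these compounds, is how a shorter or longer chain ending in a carboxylic acid would read out.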